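Thiosemicarbazones of aryl aldehydes: removing the methoxy group

The source may hold more compounds than are shown below. What is called first, only, known or untested is meant among the compounds shown, and "the series" means these compounds.

Two thiosemicarbazones have been measured so far in a functional assay on MCF7 cells (Homo sapiens) for antiproliferative activity, read by MTT assay, with a stated time of 72 h; a lower number here means a stronger inhibitor, a higher number a weaker inhibitor. Compound 1 `Oc1ccc2ccccc2c1/C=N/NC(=S)Nc1ccccc1` gives 3300 nM in this assay, and compound 2 `COc1cccc(/C=N/NC(=S)Nc2ccccc2)c1O` gives 3000 nM. Going by the values given here, the gap between these two numbers is within the scatter, so compound 2 stands on level ground with compound 1 rather than apart from it; the pair gives no step from which a direction could be read.

Compound 3 `Oc1ccccc1/C=N/NC(=S)Nc1ccccc1` is the next member and has not yet been measured. It differs from compound 2 by hydrogen in place of methoxy on an aromatic carbon, with the hydroxy group kept. Among the compounds with values here, no measured pair shows the effect of such a change, so the step is expected to stay small. Compound 3 is therefore estimated at 4000 nM in this assay, with a range of 1500 nM to 12000 nM. The expected step from compound 2 is a 1.3-fold higher number from compound 2 to compound 3 (0.12 log units; within the scatter), at most a shift hardly beyond the scatter.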

Compound 3, half-maximal inhibitory concentration: 4000 nM
The estimate for compound 3 equals the measured number at the digits printed; low and high end bracket the measured number.
By their numbers in this assay, from the lowest: compounds 2, 1 and 3 (each within the scatter of the next).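

In this assay, hydrogen in place of methoxy on the aromatic carbon ortho to the hydroxy group gives a 1.3-fold higher number from compound 2 to compound 3 (0.12 log units; within the scatter). Going by these compounds alone, this is the first step the series offers at this position, and it stays inside the scatter. With the hydroxy group kept, the methoxy group is therefore not needed at this place for a value in this range, and no measurement bears on why the step is this small.

From the compounds shown here alone, whether another group at this position, such as an amine, a carboxylic acid or a longer alkoxy chain, would give a step beyond the scatter remains open. All the compounds shown carry the hydroxy group, so what that group contributes to the numbers also remains open.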